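Swapping a methoxy for chloro on the anilino ring

The compounds below may be only part of what the source reports. "The series", "measured", "known", "first", "only" and "open" are said of these compounds alone.

Compound 3 `CCS(=O)(=O)Nc1cc(-c2ccc3ncnc(Nc4ccc(OC)c(OC)c4)c3c2)cnc1OC`: 1680 nM
Compound 1 `CCS(=O)(=O)Nc1cc(-c2ccc3ncnc(Nc4ccc(F)cc4)c3c2)cnc1OC`: 2400 nM
Compound 2 `CCS(=O)(=O)Nc1cc(-c2ccc3ncnc(Nc4ccc(OC(F)(F)F)cc4)c3c2)cnc1OC`: 22400 nM

In a functional assay on SNU-638 cells (Homo sapiens) for cytotoxicity, read by sulforhodamine B assay, with a stated time of 72 h (on this read-out lower numbers stand for stronger inhibition and higher numbers for weaker inhibition), compound 3 gives the lowest of the three numbers, but its gap to compound 1, a 1.4-fold lower number from compound 1 to compound 3 (0.15 log units; within the scatter), lies within the scatter, so the two cannot be separated. Only compound 2 stands clearly apart, as a 13-fold lower number from compound 2 to compound 3 (1.12 log units; beyond the scatter) shows.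

Compound 4 `CCS(=O)(=O)Nc1cc(-c2ccc3ncnc(Nc4ccc(OC)c(Cl)c4)c3c2)cnc1OC` differs from compound 3 in one place: chloro in place of methoxy on an aromatic carbon. Among the measured compounds shown here, no measured step touches this position alone. The step of a 9.3-fold higher number from compound 1 to compound 2 (0.97 log units; beyond the scatter) shows that a change of one substituent on the anilino ring can move the number modestly, while a 1.4-fold lower number from compound 1 to compound 3 (0.15 log units; within the scatter) shows that a broader change of that ring can leave it within the scatter. With no closer guide, the expected step of a 1.1-fold higher number from compound 3 to compound 4 (0.03 log units; within the scatter) is small, in no firm direction. Compound 4 is therefore estimated at 1800 nM, with a range of 600 nM to 6000 nM.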

Compound 4, half-maximal inhibitory concentration: 3620 nM
For compound 4 the middle estimate is 2.0-fold (0.30 log units) below the measured one; low and high end bracket the measured number.
By their numbers in this assay, from the lowest: compounds 3, 1 and 4 (each within the scatter of the next, the first and the last beyond it); then compound 2.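

In this assay, among the compounds shown here, the single swap of methoxy for chloro, ortho to a methoxy group, gives a 2.2-fold higher number from compound 3 to compound 4 (0.33 log units; beyond the scatter) and is the first direct reading at this position, so this carbon is not indifferent to its substituent, although the step is modest. The 3-chloro-4-methoxyphenyl ring stays well clear of the 4-(trifluoromethoxy)phenyl ring, with a 6.2-fold lower number from compound 2 to compound 4 (0.79 log units; beyond the scatter) as the measure, whereas a 1.5-fold higher number from compound 1 to compound 4 (0.18 log units; within the scatter) leaves it inseparable from the 4-fluorophenyl ring. Nothing shown here accounts for the step at this position.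

The compounds shown leave open how a hydroxy group, an amine or a longer ethoxy chain on this same carbon would read. A single pair also cannot tell whether the step from methoxy to chloro would hold on a different core.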